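The source may report more compounds than this note shows. Statements on the series, on what has been measured and on what is new or still open speak of the compounds shown alone.

Working notes on the series. In an assay for inhibition of histone-lysine N-methyltransferase, H3 lysine-79 specific (Homo sapiens), read by scintillation counting, with stated times of 15 min and 60 min, tested at 100 uM, in the presence of a further agent that is not named here (a higher number here means a stronger effect of the compound at the concentration tested, a lower number a weaker effect), compound 1 `C(=C/c1nn2c(-c3ccncc3)nnc2s1)\c1ccco1` gives 82%. Compound 2 `Cc1occc1-c1nnc2sc(CCc3ccccc3)nn12` gives 27%, and compound 3 `Fc1cccc(-c2nnc3sc(/C=C/c4ccco4)nn23)c1` gives 29%, the second highest of the three numbers, within the scatter of compound 2 and beyond the scatter below compound 1. Among the measured compounds shown here, the one step measured at this place, a number 53 percentage points lower from compound 1 to compound 3 (beyond the scatter), shows that the group on the aromatic carbon between two ring nitrogen atoms matters strongly. For the measured compounds named here, compound 4 `C(=C/c1nn2c(C3CCCCC3)nnc2s1)\c1ccco1` carries the change (cyclohexyl in place of 3-fluorophenyl on an aromatic carbon), for which no measured step exists; an aromatic ring is exchanged for a non-aromatic one. No direction can be read from the data, so compound 4 is expected to show a step of a number 4 percentage points lower from compound 3 to compound 4 (within the scatter), within the scatter. The estimate for compound 4 is 25%, with a range from 5% to 50%.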

Compound 4, a percentage reported as inhibition, at one concentration (the size of the read-out at that concentration, not a potency): 72%
Beside the measured number, compound 4's estimate is 47 percentage points below it; the whole stated range lies below it.
By their numbers in this assay, from the lowest: compounds 2 and 3 (each within the scatter of the next); then compounds 4 and 1 (each within the scatter of the next).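

At this aromatic carbon between two ring nitrogen atoms, an aromatic ring is not required in this assay (a number 43 percentage points higher from compound 3 to compound 4 (beyond the scatter)). Cyclohexyl, with 0 hydrogen-bond acceptors, stays level with pyridin-4-yl (a number 10 percentage points lower from compound 1 to compound 4 (within the scatter)), so the earlier drop belongs to 3-fluorophenyl and not to every replacement of pyridin-4-yl. No available evidence bears on the reason for this difference.

Open, going by these compounds, is whether the low number of 3-fluorophenyl would persist with plain phenyl. Also open, on these data alone, is how piperidin-4-yl or methyl at this carbon would read.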